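A Fluoro for Methoxy Swap Weighed Against Cell Toxicity

A few compounds are considered here, and "the series" means these few. Any claim that something is new, unique, unknown or untested is made for them only; others in the source may bear on it.

Compound 1 `COc1cc(Nc2ccnc(Nc3ccc(C#N)cc3)n2)ccc1-c1ccc(C#N)cc1`: 5260 nM
Compound 2 `N#Cc1ccc(Nc2nccc(Oc3ccc(-c4ccc(C#N)cc4)cc3F)n2)cc1`: > 307000 nM, a limit of this assay

In a functional assay on MT4 cells (Homo sapiens) for cytotoxicity, read by MTT assay, with a stated time of 5 days (on this read-out lower numbers stand for higher toxicity in this test and higher numbers for lower toxicity in this test), compound 1 gives 5260 nM, the only numerical result in this set. Compound 2 reaches only a limit of this assay, (the limit of > 307000 nM in this assay, at which 1 of the 2 values shown sits). Compound 3 `N#Cc1ccc(Nc2nccc(Nc3ccc(-c4ccc(C#N)cc4)c(F)c3)n2)cc1` differs from compound 1 by fluoro in place of methoxy on an aromatic carbon. Among the compounds with values here, no measured pair covers this change, so its effect is unknown. Compound 3 is expected to be somewhat less toxic than compound 1, the estimated step being a 2.3-fold higher number from compound 1 to compound 3 (0.36 log units; beyond the scatter), moderately beyond the scatter. Compound 3 is therefore estimated at 12000 nM, with a range from 3000 nM to 60000 nM.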

Compound 3, half-maximal cytotoxic concentration: > 271000 nM
Compound 3 gave a limit, no number; the forecaster's own chance of this, stated with the estimate: 20%; middle value at least 22-fold (1.35 log units) from the limit.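

Fluoro in place of methoxy, ortho to a 4-cyanophenyl group, gives an at least 51-fold higher number from compound 1 to compound 3 (1.71 log units; beyond the scatter) in this assay, so this single change on the shared core is enough to turn a measurable toxicity into a limit. Compound 3 gives > 271000 nM, which is a limit of the assay and not a number. The step therefore has a lower bound but no upper one.

The compounds shown leave open whether a hydroxyl, a chloro or an ethoxy group at this position would also give a limit or a number closer to that of compound 1.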